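This account rests on a few compounds, and the source may have more. Where it says the series, first, only, none or still open, it means among the compounds named here.

Within the data shown here, compound 1 `Cn1ncc(-c2cc(Cl)c3c(=O)[nH]nc(CN)c3c2)c1-c1sc2ccccc2c1C#N` is the only compound here with a definite number in an ADME assay on cells (Hepatocyte, Homo sapiens) for metabolic stability (on this read-out higher numbers stand for fast clearance and lower numbers for slow clearance), where compound 1 gives 71 mL/min/kg. Compound 2 `CCOc1cc(-c2cnn(C)c2-c2sc3ccccc3c2C#N)cc2c(CN)n[nH]c(=O)c12` reaches only a limit of this assay, and in this assay compound 2 gives < 18 mL/min/kg. Among the measured compounds shown here, the single measured step, an at least 3.9-fold lower number from compound 1 to compound 2 (0.59 log units; beyond the scatter), swaps the chloro for an ethoxy and is the one comparison that can guide what follows.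

Compound 3 `Cn1ncc(-c2cc(O)c3c(=O)[nH]nc(CN)c3c2)c1-c1sc2ccccc2c1C#N` differs from compound 1 by hydroxy in place of chloro on an aromatic carbon. Here, as in that measured step, the chloro leaves and an oxygen-bearing group enters at the same aromatic carbon, so the step from compound 1 to compound 3 is expected to run in the same direction, towards slower clearance, though with less certainty about its size since hydroxy is not ethoxy. The step of a 2.4-fold lower number from compound 1 to compound 3 (0.37 log units; beyond the scatter) is the expected outcome of this reasoning. Compound 3 is therefore estimated at 30 mL/min/kg, within a range from 14 mL/min/kg to 62 mL/min/kg.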

Compound 3, clearance: < 18 mL/min/kg
Compound 3 was reported as a limit; the forecaster's own chance of this, stated with the estimate: 30%; middle value at least 1.6-fold (0.22 log units) from the limit.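

In this assay, hydroxy in place of chloro on this aromatic carbon gives an at least 3.9-fold lower number from compound 1 to compound 3 (0.59 log units; beyond the scatter), so the drop seen with ethoxy is not confined to that one group. In the compounds shown, both oxygen-linked groups on this carbon read lower than chloro, and the smaller hydroxy, without an ethyl part, is enough to reach the limit. The step between compound 2 and compound 3 cannot be read, and hydroxy and ethoxy cannot be ranked, because both values are limits: the limit of < 18 mL/min/kg in this assay, at which 2 of the 3 values shown sit.

The compounds shown leave open whether an oxygen on this carbon is what matters, which an amine or a plain methyl group at the same place would help to settle. From the compounds shown here alone, how a longer chain on that oxygen, such as propoxy, would read also remains unknown.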